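The source may report more compounds than this note shows. Statements on the series, on what has been measured and on what is new or still open speak of the compounds shown alone.

For the measured compounds named here, compound 2 `O=[N+]([O-])c1ccc(-c2nc3ccc(Br)cc3[nH]2)cc1` holds the lowest of the two numbers so far in an assay on cells for inhibition of matrix metalloproteinase-9 (Homo sapiens), read by fluorescence, with stated times of 15 min and 4 h; on this read-out lower numbers stand for stronger inhibition and higher numbers for weaker inhibition: compound 2 gives 10000 nM, whereas compound 1 `Nc1ccc(-c2nc3ccc(Br)cc3[nH]2)cc1` gives 21700 nM. Going by the values given here, the only measured step, a 2.2-fold lower number from compound 1 to compound 2 (0.34 log units; beyond the scatter), arises from nitro in place of amino on an aromatic carbon and leaves the rest of the shared core untouched. Compound 3 `Nc1ccc2nc(-c3ccc([N+](=O)[O-])cc3)[nH]c2c1` differs from compound 2 by amino in place of bromo on an aromatic carbon. Among the compounds with values here, no measured step exchanges bromo for amino, so there is no direct precedent; what the two measured compounds show is that both numbers sit within a narrow band of weak inhibition. On that basis compound 3 is expected to stay close to compound 2, with an expected step of a 1.5-fold higher number from compound 2 to compound 3 (0.18 log units; within the scatter), not beyond the scatter. The estimate for compound 3 in this assay is 15000 nM, within 4000 nM to 50000 nM.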

Compound 3, half-maximal inhibitory concentration: > 100000 nM
Compound 3 gave a limit, no number; the forecaster's own chance of this, stated with the estimate: 15%; middle value at least 6.6-fold (0.82 log units) from the limit.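

In this assay, amino in place of bromo on this aromatic carbon gives an at least 10-fold higher number from compound 2 to compound 3 (1.00 log units; beyond the scatter), so this position on the six-membered aromatic ring responds strongly to the exchange. For the compounds shown here, the only earlier change, made on the other side of the shared core, was much smaller: a 2.2-fold lower number from compound 1 to compound 2 (0.34 log units; beyond the scatter). Compound 3 is reported only as a limit of the assay, so its step is a lower bound and not a measured size: the limit of > 100000 nM in this assay, at which 1 of the 3 values shown sits.

The compounds shown cannot separate the loss of bromo from the entry of amino, and chloro, methyl or methoxy at this position would help to tell those two apart. As far as these compounds go, how far the number for compound 3 lies past the limit remains open, as does whether a nitro or a carboxylic acid here would be better accepted than amino.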